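From furan-3-yl to thiophen-2-yl on a shared core

A few compounds are considered here, and "the series" means these few. Any claim that something is new, unique, unknown or untested is made for them only; others in the source may bear on it.

Of the compounds shown here, three have been tested so far in a functional assay on A549 cells (Homo sapiens), read by MTT assay, with a stated time of 72 h; a higher number here means a weaker inhibitor, a lower number a stronger inhibitor. Compound 3 `CNc1ncnc2c1c(-c1ccoc1)cn2[C@@H]1O[C@H](CO)[C@@H](O)[C@H]1O` gives > 20000 nM, which is a limit and not a number. Compound 1 `CSc1ncnc2c1c(-c1cccs1)cn2[C@@H]1O[C@H](CO)[C@@H](O)[C@H]1O` gives > 20000 nM, which is also a limit. Both sit at the limit of > 20000 nM in this assay, at which 2 of the 3 values shown sit, so compound 3 stands at the weak end of the values shown. For the measured compounds named here, compound 2 `CNc1ncnc2c1c(-c1ccco1)cn2[C@@H]1O[C@H](CO)[C@@H](O)[C@H]1O` is the only one with a true number, at 2570 nM.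

Compound 4 `CNc1ncnc2c1c(-c1cccs1)cn2[C@@H]1O[C@H](CO)[C@@H](O)[C@H]1O` keeps the rest of compound 3 but has thiophen-2-yl in place of furan-3-yl on an aromatic carbon. The closest measured change is an at least 7.7-fold higher number from compound 2 to compound 3 (0.89 log units; beyond the scatter), a large step that swaps furan-2-yl for furan-3-yl. Compound 4 also carries a ring joined through its 2-yl position, and that arrangement in compound 2 goes with 2570 nM. This suggests a return towards stronger inhibition. Compound 1 goes against this pattern, since it also bears thiophen-2-yl and reached no number, although it differs from compound 4 elsewhere. An estimated at least 5.0-fold lower number from compound 3 to compound 4 (0.69 log units; beyond the scatter) is therefore expected, towards a lower number in this assay. For compound 4 the estimate is 4000 nM, with an expected range from 900 nM to 20000 nM.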

Compound 4, half-maximal inhibitory concentration: > 20000 nM
Compound 4: no number, only a limit (the forecaster's own chance of this, stated with the estimate: 30%); middle value at least 5.0-fold (0.69 log units) away from the limit.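

In this assay the new result sets thiophen-2-yl against furan-2-yl on this aromatic carbon and gives an at least 7.7-fold higher number from compound 2 to compound 4 (0.89 log units; beyond the scatter), so joining a five-membered aromatic ring through its 2-yl position is not enough on its own to give a measurable value. Among compounds 2, 3 and 4, which differ only in this ring, furan-2-yl in compound 2 is now the only group that gives a true number rather than a limit. The steps from compound 3 to compound 4 and from compound 1 to compound 4 each join two limits and cannot be read, and that limit is now shared by most of the compounds shown: the limit of > 20000 nM in this assay, at which 3 of the 4 values shown sit.

How far apart the compounds at the limit really lie stays hidden, as does whether furan-2-yl would still give a number with methylsulfanyl in place of methylamino. A phenyl ring, or a furan-2-yl ring carrying a methyl group, on this same carbon would show whether anything other than unsubstituted furan-2-yl can give a measurable value here.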